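Replacing methoxy by fluoro on the 4-methoxyphenyl of compound 3

A few compounds are considered here, and "the series" means these few. Any claim that something is new, unique, unknown or untested is made for them only; others in the source may bear on it.

Compound 3 `COc1ccc(/C=C/C(=O)Nc2cc(C(=O)c3cc(OC)c(OC)c(OC)c3)cc(OC)c2OC)cc1` is, in a functional assay on HeLa cells (Homo sapiens) for cytotoxicity, read by MTT assay, with a stated time of 72 h (on this read-out higher numbers stand for weaker inhibition and lower numbers for stronger inhibition), the compound with the highest number of the three measured, giving 11200 nM. Compound 1 `COc1ccc(/C=C/C(=O)Nc2cc(C(=O)c3cc(OC)c(OC)c(OC)c3)ccc2OC)cc1` stands within the scatter of it at 10700 nM; the only gap beyond the scatter is to compound 2 `COc1ccc(/C=C/C(=O)Nc2cc(C(=O)c3cc(OC)c(OC)c(OC)c3)cc(OC)c2OC)cc1OC`, which gives 2700 nM.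

Compound 4 `COc1cc(C(=O)c2cc(OC)c(OC)c(OC)c2)cc(NC(=O)/C=C/c2ccc(F)cc2)c1OC` differs from compound 3 in one place: fluoro in place of methoxy on an aromatic carbon. Neither measured step is this change. The step of a 1.0-fold higher number from compound 1 to compound 3 (0.02 log units; within the scatter) concerns a methoxy on the other aromatic ring and shows that adding a methoxy there changes nothing beyond the scatter. The step of a 4.1-fold higher number from compound 2 to compound 3 (0.62 log units; beyond the scatter) sits on the same ring as the change now made and shows that losing a methoxy there weakens inhibition modestly. Swapping the remaining methoxy of that ring for fluoro is therefore expected to move this assay by at most a modest amount, more likely toward a higher number than a lower one, and possibly by nothing beyond the scatter.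

The expected step is a 1.3-fold higher number from compound 3 to compound 4 (0.10 log units; within the scatter). For compound 4 the estimate in this assay is 14000 nM, with a range from 5000 nM to 40000 nM.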

Compound 4, half-maximal inhibitory concentration: 900 nM
Beside the measured number, compound 4's estimate is 16-fold (1.19 log units) above it, and the stated range ends above it.
By their numbers in this assay, from the lowest: compound 4; then compound 2; then compounds 1 and 3 (each within the scatter of the next).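

Among the compounds shown here, the place para to a large group on this ring turns out to be far more sensitive than the earlier steps suggested: in this assay the change from 4-methoxyphenyl to 4-fluorophenyl gives a 12-fold lower number from compound 3 to compound 4 (1.09 log units; beyond the scatter) and is the largest step so far. The earlier drop on this ring came from adding a methoxy, yet removing the methoxy in favour of fluoro goes further, with a 3.0-fold lower number from compound 2 to compound 4 (0.48 log units; beyond the scatter) as the step between the two ring patterns, so among compounds 2, 3 and 4 the 4-methoxyphenyl of compound 3 gives the highest number and both changes to it lower the number. Nothing shown here bears on what lies behind this step.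

Going by these compounds, it remains open whether the gain belongs to fluoro itself or to the absence of methoxy at that place, a question that a plain phenyl, a 4-chlorophenyl or a 4-aminophenyl would help to settle. On these data alone, it is equally open whether the same swap holds on the core of compound 1, or whether a second fluoro on the ring adds anything further.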